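A few compounds are considered here, and "the series" means these few. Any claim that something is new, unique, unknown or untested is made for them only; others in the source may bear on it.

In a physicochemical assay for solubility, measured as kinetic solubility, at pH 6.5 (on this read-out higher numbers stand for higher solubility and lower numbers for lower solubility), compound 3 (`COc1ccc(-c2ccc3nnc([C@@H](C)c4ccc5ncccc5c4)n3n2)cc1F`) gives 10900 nM as its reading. This sits within the scatter of compound 1 (`Fc1ccc(-c2ccc3nnc(Cc4ccc5ncccc5c4)n3n2)cc1F`) at 11500 nM on the same scale, while compound 2 (`CN(C)c1ccc2nnc(Cc3ccc4ncccc4c3)n2n1`) stands well apart at 134000 nM in this series.

The change from compound 3 to compound 4 (`CNC(=O)c1ccc(-c2ccc3nnc([C@@H](C)c4ccc5ncccc5c4)n3n2)cc1`) is 4-(methylcarbamoyl)phenyl in place of 3-fluoro-4-methoxyphenyl on an aromatic carbon and the rest of the structure stays the same.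

Within the data shown here, only one measured step bears on this, and only loosely. It is a 12-fold higher number from compound 1 to compound 2 (1.07 log units; beyond the scatter) and counts as large, but there dimethylamino replaces 3,4-difluorophenyl, so a six-membered aromatic ring of carbon leaves and none enters. In the present change such a ring both leaves and enters. The closer guide is the pair of aryl-bearing compounds, with compound 1 at 11500 nM and compound 3 at 10900 nM as readings that the scatter does not separate. Among the measured compounds shown here, no measured step swaps one aryl group for another, so the size of this step remains an expectation only.

The expected outcome is a small upward move, a 1.4-fold higher number from compound 3 to compound 4 (0.14 log units; within the scatter) as estimated, with no step beyond the scatter expected. In this assay the estimate for compound 4 is 15000 nM with an expected range from 5000 nM to 45000 nM for the coming measurement.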

Compound 4, solubility: 11000 nM
Estimate against measurement, compound 4: 1.4-fold (0.13 log units) above; the range from low to high includes it.
By their numbers in this assay, from the lowest: compounds 3, 4 and 1 (each within the scatter of the next); then compound 2.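

At this position, on an aromatic carbon of the six-membered aromatic ring with 2 nitrogen, one substituted phenyl group has now been exchanged directly for another in this assay, with a 1.0-fold higher number from compound 3 to compound 4 (0.00 log units; within the scatter) for this change. The exchange is not a trivial one on paper, since 4-(methylcarbamoyl)phenyl carries 1 hydrogen-bond donor and 3-fluoro-4-methoxyphenyl carries 0, yet the two readings are not separated by the scatter. Among these compounds, the one large step remains the other kind of change, with a 12-fold higher number from compound 1 to compound 2 (1.07 log units; beyond the scatter) where dimethylamino replaces 3,4-difluorophenyl, and no supporting measurement accounts for either step.

The compounds shown leave open whether the readings would stay together with a carboxylic acid on the phenyl ring, or with a saturated amine such as morpholine in place of the phenyl ring at this position. They also leave open whether dimethylamino at this position would give a step of similar size on the core of compound 3.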